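Removing the amino group from compound 3

The source may report more compounds than this note shows. Statements on the series, on what has been measured and on what is new or still open speak of the compounds shown alone.

Measured in a functional assay on B16-F10 cells (Mus musculus) for antiproliferative activity, read by MTT assay, with a stated time of 48 h; a lower number here means a stronger inhibitor, a higher number a weaker inhibitor:
Compound 1 `COc1ccc(/C=C/c2cc(OC)cc(OC)c2/C=C/C(=O)c2cccc(OC)c2)cc1`: 4.3 ug/mL
Compound 2 `COc1ccc(/C=C/c2cc(OC)cc(OC)c2/C=C/C(=O)c2ccc(Br)cc2)cc1`: 6.5 ug/mL
Compound 3 `COc1ccc(/C=C/c2cc(OC)cc(OC)c2/C=C/C(=O)c2ccc(N)cc2)cc1`: 2.8 ug/mL

Compound 3 stands at 2.8 ug/mL in this assay, level with compound 1 within the scatter and clearly apart from compound 2. Compound 4 `COc1ccc(/C=C/c2cc(OC)cc(OC)c2/C=C/C(=O)c2ccccc2)cc1` carries hydrogen in place of amino on an aromatic carbon, para to a large group: hydrogen in place of amino on an aromatic carbon. Going by the values given here, no measured step makes this exact change. The closest are a 2.3-fold lower number from compound 2 to compound 3 (0.37 log units; beyond the scatter) and a 1.5-fold lower number from compound 1 to compound 3 (0.19 log units; within the scatter), and both arrive at the amino compound with a lower number. Losing the amino group is therefore expected to move the number modestly upward, perhaps no further than the scatter. The estimated change is a 1.6-fold higher number from compound 3 to compound 4 (0.20 log units; within the scatter). The expected value for compound 4 is 4.4 ug/mL, within an estimated range of 2.4 ug/mL to 8 ug/mL.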

Compound 4, half-maximal inhibitory concentration: 3.7 ug/mL
For compound 4 the middle estimate is 1.2-fold (0.08 log units) above the measured one; measured number inside the range.
By their numbers in this assay, from the lowest: compounds 3, 4, 1 and 2 (each within the scatter of the next, the first and the last beyond it).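

In this assay the plain phenyl of compound 4 stands apart from none of the others, with a 1.3-fold higher number from compound 3 to compound 4 (0.12 log units; within the scatter) and a 1.8-fold lower number from compound 2 to compound 4 (0.24 log units; within the scatter) and a 1.2-fold lower number from compound 1 to compound 4 (0.07 log units; within the scatter) all within the scatter. Hydrogen on this ring thus sits within the scatter of amino, bromo and methoxy alike, though the amino and bromo compounds remain separated by a 2.3-fold lower number from compound 2 to compound 3 (0.37 log units; beyond the scatter) as the only step beyond it. Nothing available speaks to the reason for this.

Open, as far as these compounds go, is whether a carboxylic acid or a longer chain in place of the amino group would stay this close to compound 4.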